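Shifting the hydroxyl group from compound 2 to compound 4

The source may hold more compounds than are shown below. What is called first, only, known or untested is meant among the compounds shown, and "the series" means these compounds.

Of the compounds shown here, three built on one shared core have been measured in an assay on isolated protein for inhibition of DNA topoisomerase 1 (Homo sapiens), with a stated time of 30 min, tested at 100 uM; a lower number here means a weaker effect, a higher number a stronger effect of the compound at the concentration tested. Compound 1 `Oc1ccc(-c2cc(-c3ccccn3)nc(-c3ccccc3Cl)c2)cc1` gives 5.2%. Compound 2 `Oc1ccc(-c2cc(-c3cccs3)nc(-c3ccccc3Cl)c2)cc1` gives 2.2%. Compound 3 `Oc1ccc(-c2cc(-c3ccncc3)nc(-c3ccccc3Cl)c2)cc1` gives 9.9%. Compound 2 holds the lowest of these three numbers, but the gaps around it are small: the step of a number 3 percentage points lower from compound 1 to compound 2 (within the scatter) and the step of a number 7.7 percentage points higher from compound 2 to compound 3 (within the scatter) are both within the scatter, as is the step of a number 4.7 percentage points higher from compound 1 to compound 3 (within the scatter). Compound 4 `Oc1cccc(-c2cc(-c3cccs3)nc(-c3ccccc3Cl)c2)c1` differs from compound 2 in one place: 3-hydroxyphenyl in place of 4-hydroxyphenyl on an aromatic carbon. Among the measured compounds shown here, none of the measured steps changes this hydroxyphenyl group; each of them swaps the pyridinyl or thiophenyl ring on the far side of the core, and every one of them stays within the scatter. For the measured compounds named here, there is therefore no measured step that bears directly on the change, and all three compounds sit close to the bottom of the read-out. The expected step in this assay is accordingly a number 1.8 percentage points higher from compound 2 to compound 4 (within the scatter), that is, none beyond the scatter. Compound 4 is estimated to give 4%, with a range from 0% to 14%.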

Compound 4, a percentage reported as inhibition, at one concentration (the size of the read-out at that concentration, not a potency): 2.7%
Compound 4: middle estimate off by 1.3 percentage points, on the high side, within the range that was stated.
By their numbers in this assay, from the lowest: compounds 2, 4, 1 and 3 (each within the scatter of the next).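

In this assay, 3-hydroxyphenyl in place of 4-hydroxyphenyl is the only step shown that alters this group, and it gives a number 0.5 percentage points higher from compound 2 to compound 4 (within the scatter) with the thiophen-2-yl group held constant. The place of the hydroxyl on this ring therefore makes no difference beyond the scatter here, but compound 2 and compound 4 both sit so near the bottom of the read-out that a loss could hardly show. No measurement shown offers an explanation for this result.

As far as these compounds go, whether the same shift would matter with the pyridin-4-yl group of compound 3 in place of the thiophen-2-yl group remains open. From the compounds shown here alone, it is also open whether an amine or a carboxylic acid in place of the hydroxyl would move the read-out at all.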